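This account rests on a few compounds, and the source may have more. Where it says the series, first, only, none or still open, it means among the compounds named here.

In a functional assay on HOP-62 cells (Homo sapiens) for inhibition, read by sulforhodamine B assay (on this read-out higher numbers stand for weaker inhibition of growth and lower numbers for stronger inhibition of growth), compound 1 `Cc1ccc2[nH]c(-c3ccc(-c4ccc(-c5cccc(Cl)c5)cc4)cc3)nc2c1` gives 2740 nM, the lowest of three numbers, against compound 2 `CN(C)c1ccc(-c2ccc(-c3ccc(-c4nc5ccccc5[nH]4)cc3)cc2)cc1` at 100000 nM and compound 3 `Clc1cccc(-c2ccc(-c3ccc(-c4nc5ccccc5[nH]4)cc3)cc2)c1` at 100000 nM. Compound 4 `Cc1ccc2[nH]c(-c3ccc(-c4ccc(-c5ccc(O)cc5)cc4)cc3)nc2c1` keeps the core of compound 1 and exchanges one group: 4-hydroxyphenyl in place of 3-chlorophenyl on an aromatic carbon. Hydrogen in place of methyl gave a 36-fold higher number from compound 1 to compound 3 (1.56 log units; beyond the scatter), but compound 4 retains that methyl. The closest measured exchange, 3-chlorophenyl in place of 4-(dimethylamino)phenyl, gave no change at the digits printed from compound 2 to compound 3 (within the scatter), though on a core lacking the methyl. No step beyond the scatter is therefore expected in this assay, with a wider allowance towards higher numbers. The estimate is a 1.5-fold higher number from compound 1 to compound 4 (0.16 log units; within the scatter). For compound 4 the expected value is 4000 nM, with an estimated range of 1000 nM to 40000 nM.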

Compound 4, concentration for 50% growth inhibition: 41200 nM
Compound 4: middle estimate off by 10-fold (1.01 log units), on the low side, outside the stated range (above it).
By their numbers in this assay, from the lowest: compound 1; then compound 4; then compounds 2 and 3 (each within the scatter of the next).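

In this assay, this position proves sensitive on the core that carries the methyl: 4-hydroxyphenyl in place of 3-chlorophenyl gave a 15-fold higher number from compound 1 to compound 4 (1.18 log units; beyond the scatter), whereas the earlier exchange at this place, on the core lacking the methyl, gave no change at the digits printed from compound 2 to compound 3 (within the scatter). Nothing available explains the higher number for compound 4. The compounds shown leave open whether the step follows from losing the chlorine or from gaining the hydroxyl. An unsubstituted phenyl, or a methoxy group or carboxylic acid on this ring, would help separate the two.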